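The source may hold more compounds than are shown below. What is called first, only, known or untested is meant among the compounds shown, and "the series" means these compounds.

Compound 1 `Nc1ccccc1NC(=O)c1ccc(CSC(=S)N2CCN(C3CCCCC3)CC2)cc1` was tested in a functional assay on MGC-803 cells (Homo sapiens) for antiproliferative activity, read by CCK-8 assay, with a stated time of 72 h, tested at 2 uM (on this read-out lower numbers stand for a weaker effect and higher numbers for a stronger effect at the one concentration tested), where compound 1 gives 16.9%. That is the lowest of the three numbers shown. Compound 2 `Nc1ccccc1NC(=O)c1ccc(CSC(=S)N2CCc3cc([N+](=O)[O-])ccc32)cc1` gives 26.8%, a number that lies within the scatter of compound 1, so no order between the two can be read. Compound 3 `CN(Cc1ccncc1)C(=S)SCc1ccc(C(=O)Nc2ccccc2N)cc1` gives 38.1%, which stands beyond the scatter above compound 1. Compound 4 `Nc1ccccc1NC(=O)c1ccc(CSC(=S)N2CCN(Cc3ccccc3)CC2)cc1` has not yet been measured. It differs from compound 1 in one place: benzyl in place of cyclohexyl on an amine nitrogen in a ring. Within the data shown here, no measured pair shows this exact change, so the expectation rests only on the spread of the three numbers. The step that this estimate means is a number 7.1 percentage points higher from compound 1 to compound 4 (within the scatter), and it is expected to stay within the scatter. Compound 4 is therefore estimated at 24%, with a range from 10% to 40%.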

Compound 4, a percentage reported as inhibition, at one concentration (the size of the read-out at that concentration, not a potency): 18.1%
Compound 4: middle estimate off by 5.9 percentage points, on the high side; the measured number falls inside the stated range.
By their numbers in this assay, from the lowest: compounds 1, 4 and 2 (each within the scatter of the next); then compound 3.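

On the amine nitrogen in the ring, benzyl in place of cyclohexyl reads as a number 1.2 percentage points higher from compound 1 to compound 4 (within the scatter) in this assay. Among these compounds, this is the first step read at this position, and it shows that an aromatic and a non-aromatic six-membered ring of carbon only cannot be told apart here at the one concentration tested. Nothing measured here gives a reason for this result.

On these data alone, it remains open whether a small group such as methyl, or an acetyl group, on this nitrogen would also fall within the scatter of compound 1.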